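Compound 3: one chain carbon more than compound 1

This account rests on a few compounds, and the source may have more. Where it says the series, first, only, none or still open, it means among the compounds named here.

In an ADME assay on HEL cells (Homo sapiens) for cytotoxicity, with a stated time of 3 days (a lower number here means that less compound is tolerated, a higher number that more compound is tolerated), compound 1 (`CCCCCc1cnc(-c2cc3cn([C@H]4C[C@H](O)[C@@H](CO)O4)c(=O)nc3o2)nc1`) gives > 50000 nM as a limit, not a number. Compound 2 (`CCCc1ccc(CCc2cc3cn([C@H]4C[C@H](O)[C@@H](CO)O4)c(=O)nc3o2)cc1`) gives > 130000 nM as a limit too. Compound 1 therefore stands on a limit, and neither value shown is a number. Compound 3 (`CCCCCCc1cnc(-c2cc3cn([C@H]4C[C@H](O)[C@@H](CO)O4)c(=O)nc3o2)nc1`) differs from compound 1 by methyl in place of hydrogen on a saturated chain carbon, five bonds along the chain from an aromatic carbon in one place: methyl in place of hydrogen on a saturated chain carbon, five bonds along the chain from an aromatic carbon. No step beyond the scatter is expected in this assay, and the estimated step is a step that the limit leaves unreadable from compound 1 to compound 3 at most. The expected value for compound 3 is 60000 nM with an estimated range from 20000 nM to 150000 nM as its ends.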

Compound 3, half-maximal cytotoxic concentration: > 50000 nM
Compound 3 ended at the assay's limit (the forecaster's own chance of this, stated with the estimate: 70%); the middle value does not contradict the limit.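

In this assay no step can be read from compound 1 to compound 3, as both values are limits, not numbers. The compounds shown leave open whether methyl in place of hydrogen on this saturated chain carbon changes the half-maximal cytotoxic concentration at all.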